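Two Dihydropyrimidine Curcuminoids Measured, a Dichlorophenyl Analogue Awaited

The source may report more compounds than this note shows. Statements on the series, on what has been measured and on what is new or still open speak of the compounds shown alone.

Compound 1 `COc1cc(/C=C/C(=O)C2=C(/C=C/c3ccc(O)c(OC)c3)NC(=O)NC2c2ccccc2)ccc1O` — in a functional assay, with a stated time of 20 min, tested at 20 uM (a higher number here means a stronger effect of the compound at the concentration tested, a lower number a weaker effect), compound 1 gives 31%.
Compound 2 `COc1cc(/C=C/C(=O)C2=C(/C=C/c3ccc(O)c(OC)c3)NC(=S)NC2c2ccc(C)cc2)ccc1O` — in this assay compound 2 gives 30%.

Compound 2 shows the lower of the two numbers in this assay, yet its gap to compound 1 lies within the scatter, so the two stand level. Compound 3 `COc1cc(/C=C/C(=O)C2=C(/C=C/c3ccc(O)c(OC)c3)NC(=S)NC2c2c(Cl)cccc2Cl)ccc1O` differs from compound 2 in one place: 2,6-dichlorophenyl in place of 4-methylphenyl on a saturated ring carbon. Among the compounds with values here, no measured pair shows what such a change does here. Since compound 2 and compound 1 carry different aryl groups at that carbon and still give matching activity, a small step is expected, no change at the digits printed from compound 2 to compound 3 (within the scatter). Compound 3 is estimated at 30%, between 12% and 48%.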

Compound 3, a percentage reported as activity, at one concentration (the size of the read-out at that concentration, not a potency): 33.9%
Compound 3: middle estimate off by 3.9 percentage points, on the low side; measured number inside the range.
By their numbers in this assay, from the lowest: compounds 2, 1 and 3 (each within the scatter of the next).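

In this assay the swap of 4-methylphenyl for 2,6-dichlorophenyl on the saturated ring carbon gives a number 3.9 percentage points higher from compound 2 to compound 3 (within the scatter) and so stays inside the usual spread of repeats. This position therefore accepts an aryl group carrying two chlorine atoms, in place of one carrying a methyl group, with no readable shift in the percentage. Nothing at hand bears on the reason for this result. As far as these compounds go, whether an aryl group bearing an amine or a carboxylic acid, or a longer chain in place of the aryl group, would give a readable shift stays open.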